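A few compounds are considered here, and "the series" means these few. Any claim that something is new, unique, unknown or untested is made for them only; others in the source may bear on it.

Compound 1 `CC1=CC[C@H](C(C)C)c2cc(C)c(OC(=O)c3ccc(Cl)cc3)cc21` is an ester built on a shared core, and in a functional assay on HCT-15 cells (Homo sapiens) for antiproliferative activity, read by sulforhodamine B assay, with a stated time of 48 h, tested at 50 uM (on this read-out lower numbers stand for less inhibition and higher numbers for more inhibition at the one concentration tested (going by the name of the read-out)), compound 1 gives 47.4%. Among the three measured compounds this places compound 1 in the middle: compound 2 `COc1ccc(C(=O)Oc2cc3c(C)ccc(C(C)C)c3cc2C)cc1` reads 84% in this assay, while compound 3 `CC1=CC[C@H](C(C)C)c2cc(C)c(OC(=O)c3ccc(C(F)(F)F)cc3)cc21` reads 6.4%. Going by the values given here, the one measured step between single-change neighbours is a number 41 percentage points lower from compound 1 to compound 3 (beyond the scatter), which shows how strongly a change on the aromatic ring of the ester can move the number.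

Compound 4 `CC1=CC[C@H](C(C)C)c2cc(C)c(OC(=O)Nc3ccccc3)cc21` differs from compound 1 in a different way: anilino in place of 4-chlorophenyl on a carbonyl carbon. Among the compounds with values here, this turns the ester into a carbamate carrying an anilino group, and none of the measured steps touches this kind of change. Within the data shown here, no step among the measured compounds therefore bears directly on the expected direction, so the estimate for compound 4 rests mainly on where compound 1 stands, with a wide range.

Compound 4 is expected to give about 42% in this assay, somewhere between 10% and 75%. That estimate means a step of a number 5.4 percentage points lower from compound 1 to compound 4 (within the scatter), which is expected to stay within the scatter.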

Compound 4, a percentage reported as inhibition, at one concentration (the size of the read-out at that concentration, not a potency): 92%
Compound 4: middle estimate off by 50 percentage points, on the low side; measured number outside the range, above it.
By their numbers in this assay, from the lowest: compound 3; then compound 1; then compounds 2 and 4 (each within the scatter of the next).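

In this assay the swap of 4-chlorophenyl for anilino on the carbonyl carbon gives a number 44.6 percentage points higher from compound 1 to compound 4 (beyond the scatter) and so turns the ester into a carbamate with a clearly higher number. The earlier step of a number 41 percentage points lower from compound 1 to compound 3 (beyond the scatter) changed only a substituent on the aromatic ring and moved the number down, so this result adds that changing the link to that ring can move it up by a similar size, and that the shared core can carry a carbamate at this place. No measurement shown explains this rise.

Going by these compounds, this one step changes two things together, since the chloro group goes as the nitrogen with its hydrogen-bond donor comes in, so their separate shares remain unknown. A 4-chloroanilino group would separate them, and an N-methylanilino or a cyclohexylamino group would test how much the amide hydrogen and the aromatic ring matter.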